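Fluoro in place of dimethylamino on compound 2

A few compounds are considered here, and "the series" means these few. Any claim that something is new, unique, unknown or untested is made for them only; others in the source may bear on it.

In a functional assay on A549 cells (Homo sapiens) for inhibition, read by sulforhodamine B assay, with a stated time of 48 h (a lower number here means a stronger inhibitor of growth, a higher number a weaker inhibitor of growth), compound 1 `COc1cc(C=C(C(=O)/C=C/c2ccc(OC)c(OC)c2)C(=O)/C=C/c2ccc(OC)c(OC)c2)ccc1O` gives 530 nM. Among the compounds with values here, compound 2 `COc1ccc(/C=C/C(=O)C(=Cc2ccc(N(C)C)cc2)C(=O)/C=C/c2ccc(OC)c(OC)c2)cc1OC` gives 2620 nM, the higher of the two numbers so far. Compound 3 `COc1ccc(/C=C/C(=O)C(=Cc2ccc(F)cc2)C(=O)/C=C/c2ccc(OC)c(OC)c2)cc1OC` has fluoro in place of dimethylamino on an aromatic carbon, para to a large group: fluoro in place of dimethylamino on an aromatic carbon. Within the data shown here, no measured compound carries fluoro, so nothing shows this change directly. Among the measured compounds shown here, the only measured step bearing on it is a 4.9-fold higher number from compound 1 to compound 2 (0.69 log units; beyond the scatter), a modest step with 4-(dimethylamino)phenyl in place of 4-hydroxy-3-methoxyphenyl. It touches the same aryl group, so a modest step is expected here too, smaller than that one and toward the value of compound 1 at 530 nM, though the direction remains uncertain. The expected step is a 2.2-fold lower number from compound 2 to compound 3 (0.34 log units; beyond the scatter). The estimated value for compound 3 is 1200 nM, with an expected range of 400 nM to 3500 nM.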

Compound 3, concentration for 50% growth inhibition: 550 nM
For compound 3 the middle estimate is 2.2-fold (0.34 log units) above the measured one, and the stated range covers the measured number.
By their numbers in this assay, from the lowest: compounds 1 and 3 (each within the scatter of the next); then compound 2.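

In this assay, the aromatic carbon carrying dimethylamino in compound 2 proves sensitive to its substituent: fluoro in place of dimethylamino gives a 4.8-fold lower number from compound 2 to compound 3 (0.68 log units; beyond the scatter). The aryl group also need not keep the hydroxy and methoxy groups of compound 1 to hold that level, as 4-fluorophenyl in their place gives a 1.0-fold higher number from compound 1 to compound 3 (0.02 log units; within the scatter), so the higher number of compound 2 goes with 4-(dimethylamino)phenyl rather than with every replacement of that aryl group. No measurement at hand accounts for the difference between fluoro and dimethylamino.

Going by these compounds, whether the shift reflects the arrival of fluoro or only the departure of dimethylamino remains open. Chloro, trifluoromethyl or a primary amine on the same aromatic carbon would help separate the two readings.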